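This account rests on a few compounds, and the source may have more. Where it says the series, first, only, none or still open, it means among the compounds named here.

Measured in a functional assay on A549 cells (Homo sapiens) for cytotoxicity, read by MTT assay, with a stated time of 48 h; on this read-out lower numbers stand for stronger inhibition and higher numbers for weaker inhibition:
- compound 1 `COc1c(OCc2cnoc2C)cc(O)c2c(=O)cc(-c3ccccc3)oc12`: > 100000 nM (a limit, not a number)
- compound 2 `COc1c(OCCCCN2CCNCC2)cc(O)c2c(=O)cc(-c3ccccc3)oc12`: 1740 nM
- compound 3 `CCN(CC)CCCOc1cc(O)c2c(=O)cc(-c3ccccc3)oc2c1OC`: 1830 nM

Only two of these compounds have true numbers, and they cannot be told apart: a 1.1-fold higher number from compound 2 to compound 3 (0.02 log units; within the scatter). Compound 1 gives only a limit, so it cannot be placed exactly.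

The next compound is compound 4 `COc1c(OCCCN2CCNCC2)cc(O)c2c(=O)cc(-c3ccccc3)oc12`, which keeps the chain of compound 3 but changes the group at its end: piperazin-1-yl in place of diethylamino on a saturated chain carbon, three bonds along the chain from an oxygen on an aromatic ring. In other words, 3-(diethylamino)propyl becomes 3-(piperazin-1-yl)propyl.

For the measured compounds named here, the closest evidence is the step that links the same two end groups, although there the piperazine sits on a chain that differs from the one in compound 3. That step stayed within the scatter: a 1.1-fold higher number from compound 2 to compound 3 (0.02 log units; within the scatter). The two large steps, an at least 57-fold lower number from compound 1 to compound 2 (1.75 log units; beyond the scatter) and an at least 54-fold lower number from compound 1 to compound 3 (1.73 log units; beyond the scatter), replace the 5-methyl-1,2-oxazol-4-yl group, which is absent from compound 4. Both chains ending in these groups gave similar values, so no step beyond the scatter is expected here.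

The estimated step is a 1.0-fold lower number from compound 3 to compound 4 (0.01 log units; within the scatter). For compound 4 the expected value is 1800 nM, with an estimated range of 800 nM to 4500 nM.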

Compound 4, half-maximal inhibitory concentration: 10100 nM
Compound 4: the middle estimate sits 5.6-fold (0.75 log units) below what was measured, and the stated range ends below it.
By their numbers in this assay, from the lowest: compounds 2 and 3 (each within the scatter of the next); then compound 4. At a limit, above all of these: compound 1.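

The 3-(piperazin-1-yl)propyl and 3-(diethylamino)propyl chains are not interchangeable in this assay: with the chain held constant, the change of end group gives a 5.5-fold higher number from compound 3 to compound 4 (0.74 log units; beyond the scatter). The earlier match between compound 2 and compound 3 therefore does not show that these two end groups are equivalent, since that pair also differed in chain, and compound 2 goes against any simple ranking of piperazin-1-yl below diethylamino. With the piperazin-1-yl end kept, chain length matters too, as the shorter chain gives a 5.8-fold higher number from compound 2 to compound 4 (0.76 log units; beyond the scatter), while compound 4 still stands clear of compound 1, whose entry is a limit and not a number, with an at least 9.9-fold lower number from compound 1 to compound 4 (0.99 log units; beyond the scatter): the limit of > 100000 nM in this assay, at which 1 of the 4 values shown sits.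

On these data alone, it remains open whether a diethylamino end would respond to a change in chain length as the piperazin-1-yl end does. Also unsettled is where a morpholine, a piperidine or a 4-methylpiperazine end on the 3-propyl chain would fall, or what a chain longer than that of compound 2 would give.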